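Shortening the basic side chain from compound 1

A few compounds are considered here, and "the series" means these few. Any claim that something is new, unique, unknown or untested is made for them only; others in the source may bear on it.

For the measured compounds named here, compound 1 `CCN(CC)CCCCOc1c(OCc2ccccc2)cc2oc(-c3ccccc3)cc(=O)c2c1O` gives 4200 nM in a functional assay on BCG823 cells (Homo sapiens) for antiproliferative activity, read by MTT assay, with a stated time of 48 h (on this read-out lower numbers stand for stronger inhibition and higher numbers for weaker inhibition), the lowest of the three numbers so far. Going by the values given here, compound 3 `COc1cc2oc(-c3ccccc3)cc(=O)c2c(O)c1OCCCCN1CCCC1` gives 10600 nM and compound 2 `O=c1cc(-c2ccccc2)oc2cc(O)c(OCCCCN3CCCC3)c(O)c12` gives 86400 nM; the only single-point step among them, an 8.2-fold lower number from compound 2 to compound 3 (0.91 log units; beyond the scatter), concerns an oxygen on the aromatic ring and not the basic chain. Compound 4 `CN(C)CCCOc1c(OCc2ccccc2)cc2oc(-c3ccccc3)cc(=O)c2c1O` differs from compound 1 by dimethylamino in place of (diethylamino)methyl on a saturated chain carbon, three bonds along the chain from an oxygen on an aromatic ring. Among the compounds with values here, no measured step bears on this change; compounds 2 and 3 carry their own chain on a different pattern of substituents on the shared core and offer no comparison. Compound 4 is therefore expected to stay near compound 1, a step of a 1.4-fold higher number from compound 1 to compound 4 (0.15 log units; within the scatter) at most slightly beyond the scatter. The estimate for compound 4 is 6000 nM, within 2500 nM to 15000 nM.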

Compound 4, half-maximal inhibitory concentration: 5500 nM
Estimate against measurement, compound 4: 1.1-fold (0.04 log units) above; measured number inside the range.
By their numbers in this assay, from the lowest: compounds 1, 4 and 3 (each within the scatter of the next, the first and the last beyond it); then compound 2.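

In this assay, for the compounds shown here, 3-(dimethylamino)propyl replaces 4-(diethylamino)butyl with a 1.3-fold higher number from compound 1 to compound 4 (0.12 log units; within the scatter), the first reading on the basic chain at this oxygen of the shared core. On this benzyl-bearing pattern, the change in amine and chain together leaves the number within the scatter. Because the two parts change at once, the pair cannot show either alone.

A 3-(diethylamino)propyl or 4-(dimethylamino)butyl chain would separate the amine from the chain length, and a morpholine would test a different amine at this position. No measurement shown explains why the number holds across this change.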